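From fluoro to methyl: estimating the clearance of compound 3

The source may report more compounds than this note shows. Statements on the series, on what has been measured and on what is new or still open speak of the compounds shown alone.

Measured so far in an in vitro ADME assay on microsomes from liver (Homo sapiens) for pharmacokinetics, read by LC-MS, with a stated time of 10 min, tested at 1 uM (on this read-out higher numbers stand for fast clearance and lower numbers for slow clearance), are these two compounds:
- compound 1 `CN1C[C@H](C(=O)Nc2ccc(Br)cc2)[C@@H](c2ccc(/C=C/C(=O)Nc3ccccc3N)cc2)C1` gives 3 mL/min/kg
- compound 2 `CN1C[C@H](C(=O)Nc2cccc(F)c2)[C@@H](c2ccc(/C=C/C(=O)Nc3ccccc3N)cc2)C1` gives 6 mL/min/kg

For the measured compounds named here, with only two numbers available, compound 2 can be placed against just one neighbour. Compound 2, at 6 mL/min/kg in this assay, lies within the usual scatter of compound 1, so the two values cannot be told apart.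

The next compound is compound 3 `Cc1cccc(NC(=O)[C@H]2CN(C)C[C@@H]2c2ccc(/C=C/C(=O)Nc3ccccc3N)cc2)c1`, which keeps the shared core of compound 2 and alters one group (methyl in place of fluoro on an aromatic carbon). Here 3-fluorophenyl becomes 3-methylphenyl, with methyl in place of fluoro on an aromatic carbon.

Going by the values given here, the one measured step that bears on this (a 2.0-fold higher number from compound 1 to compound 2 (0.30 log units; within the scatter)) also swapped the aromatic group on an amide-type nitrogen, and it stayed within the scatter. Among the compounds with values here, no measured compound carries the methyl, so the data suggest no direction. The expected change is therefore none beyond the scatter, and the estimated step is no change at the digits printed from compound 2 to compound 3 (within the scatter) in this assay for now. For compound 3 the estimated clearance is 6 mL/min/kg (expected range 3 mL/min/kg to 13 mL/min/kg).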

Compound 3, clearance: 14 mL/min/kg
The estimate for compound 3 lay 2.3-fold (0.37 log units) below the measured number, outside the stated range (above it).
By their numbers in this assay, from the lowest: compounds 1 and 2 (each within the scatter of the next); then compound 3.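

In this assay, methyl in place of fluoro gives a 2.3-fold higher number from compound 2 to compound 3 (0.37 log units; beyond the scatter). This is a swap of one heavy atom for another, with no ring, charge or hydrogen-bond donor or acceptor entering or leaving, yet it is the first step among these compounds to go beyond the scatter. The wider comparison gives a 4.7-fold higher number from compound 1 to compound 3 (0.67 log units; beyond the scatter), also beyond the scatter, so the 3-methylphenyl compound stands apart from both the 3-fluorophenyl and the 4-bromophenyl compounds, which could not be told apart from each other. Nothing measured here accounts for the higher number seen with the methyl.

On these data alone, these steps are modest and rest on one compound carrying the methyl, so it remains open whether an ethyl, a methoxy or a chloro on the same aromatic carbon would give a number closer to that of compound 2 or to that of compound 3. As far as these compounds go, it is also open whether the same swap of fluoro for methyl would give a similar step on a different core, since a single pair cannot show how general the change is.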